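The source may report more compounds than this note shows. Statements on the series, on what has been measured and on what is new or still open speak of the compounds shown alone.

Compound 1 (`COc1ccccc1Oc1c(N)nc(-c2ccccc2)nc1OCCO`), with a phenyl group on the shared core, gives 31100 nM in a functional assay on B16 cells (Mus musculus) for cytotoxicity, read by CCK-8 assay, with a stated time of 24 h (a higher number here means a weaker inhibitor, a lower number a stronger inhibitor), as the starting point. Compound 2 (`COc1ccccc1Oc1c(N)nc(-c2ccc(C)cc2)nc1OCCO`), with a 4-methylphenyl group, gives 8430 nM there, and compound 3 (`COc1ccccc1Oc1c(N)nc(-c2cccc(Cl)c2)nc1OCCO`), with a 3-chlorophenyl group, gives 5010 nM there. The standing of compound 3 rests on two steps: a 6.2-fold lower number from compound 1 to compound 3 (0.79 log units; beyond the scatter) clears the scatter, while a 1.7-fold lower number from compound 2 to compound 3 (0.23 log units; within the scatter) does not. Compound 4 (`COc1ccccc1Oc1c(N)nc(-c2ccc(Br)cc2)nc1OCCO`) has 4-bromophenyl in place of 3-chlorophenyl (4-bromophenyl in place of 3-chlorophenyl on an aromatic carbon) on the aromatic carbon between two ring nitrogen atoms. Within the data shown here, no bromo compound has yet been measured, so the evidence is indirect. Among the measured compounds shown here, with a 3.7-fold lower number from compound 1 to compound 2 (0.57 log units; beyond the scatter) and a 6.2-fold lower number from compound 1 to compound 3 (0.79 log units; beyond the scatter) pointing the same way, and no measured compound going against them, compound 4 is expected to stay close to compound 3 as another substituted phenyl. The expected change is a 1.2-fold higher number from compound 3 to compound 4 (0.06 log units; within the scatter) and so none beyond the scatter. The estimated value for compound 4 is 5800 nM with an expected range from 2500 nM to 13000 nM in this assay here.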

Compound 4, half-maximal inhibitory concentration: 11800 nM
Beside the measured number, compound 4's estimate is 2.0-fold (0.31 log units) below it; low and high end bracket the measured number.
By their numbers in this assay, from the lowest: compounds 3, 2 and 4 (each within the scatter of the next, the first and the last beyond it); then compound 1.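

Substituted phenyl groups on the aromatic carbon between two ring nitrogen atoms prove not to be interchangeable, as replacing 3-chlorophenyl with 4-bromophenyl moves the number beyond the scatter (a 2.4-fold higher number from compound 3 to compound 4 (0.37 log units; beyond the scatter)). The 4-bromophenyl group still keeps compound 4 on the low side of the unsubstituted phenyl (a 2.6-fold lower number from compound 1 to compound 4 (0.42 log units; beyond the scatter)), so all three substituted compounds now share that direction, while compound 4 remains within the scatter of the 4-methylphenyl compound (a 1.4-fold higher number from compound 2 to compound 4 (0.15 log units; within the scatter)). Nothing available accounts for the gap between the chloro and bromo compounds.

This swap changes both the halogen and its place on the phenyl ring, and the compounds shown do not separate the two. Also open, from the compounds shown here alone, is how a phenyl ring carrying an amine or a carboxylic acid would behave at this position.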